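Halogen swap on the amide aryl ring

The source may report more compounds than this note shows. Statements on the series, on what has been measured and on what is new or still open speak of the compounds shown alone.

Measured so far:
compound 1 `O=C(Nc1ccc(Cl)c(-c2nnc3c(Cl)cccn23)c1)c1ccc(C(F)(F)F)cc1F`: 41200 nM
compound 2 `O=C(Nc1ccc(Cl)c(-c2nnc3c(Cl)cccn23)c1)c1c(F)cccc1Cl`: a limit in this assay, given below

Among the measured compounds shown here, in a functional assay on AN3-CA cells (Homo sapiens) for antiproliferative activity, read by MTT assay, with a stated time of 72 h (a lower number here means a stronger inhibitor, a higher number a weaker inhibitor), compound 1 gives 41200 nM, the only numerical value shown. Compound 2 reaches only the limit of > 100000 nM in this assay (the limit of > 100000 nM in this assay, at which 1 of the 2 values shown sits). Compound 3 `O=C(Nc1ccc(Cl)c(-c2nnc3c(Cl)cccn23)c1)c1ccc(C(F)(F)F)cc1Cl` differs from compound 1 by chloro in place of fluoro on an aromatic carbon. No step between two measured compounds is shown, so the size of this change is not yet anchored. The swap is expected to move the value in this assay by little, within or just beyond the scatter, in no settled direction. Compound 3 is estimated at 45000 nM (range 15000 nM to 130000 nM), a step of a 1.1-fold higher number from compound 1 to compound 3 (0.04 log units; within the scatter).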

Compound 3, half-maximal inhibitory concentration: > 100000 nM
Compound 3 gave a limit, no number; the forecaster's own chance of this, stated with the estimate: 25%; at least 2.2-fold (0.34 log units) between middle value and limit.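

At this position, ortho to a large group and meta to a trifluoromethyl group, chloro in place of fluoro is not a neutral swap in this assay: the series shows an at least 2.4-fold higher number from compound 1 to compound 3 (0.38 log units; beyond the scatter). Compound 3 has a limit rather than a number, so this step gives only the minimum size of the change. Compound 1 remains the only compound with a number, and the series is crowded against the top of the measurable range: the limit of > 100000 nM in this assay, at which 2 of the 3 values shown sit.

On these data alone, how far compound 3 lies past its limit stays open. Also open, as far as these compounds go, is whether a methyl group or an amine at this position would give a number.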